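The source may report more compounds than this note shows. Statements on the series, on what has been measured and on what is new or still open speak of the compounds shown alone.

Compound 1, `COC(=O)[C@@H](C)NC(=O)Cn1cc(C2=C(c3c[nH]c4ccccc34)C(=O)N(C)C2=O)c2ccccc21`, in a functional assay on A549 cells (Homo sapiens) for cytotoxicity, read by MTT assay, with a stated time of 24 h; a lower number here means a stronger inhibitor, a higher number a weaker inhibitor: 30500 nM
Compound 2, `COC(=O)CCNC(=O)Cn1cc(C2=C(c3c[nH]c4ccccc34)C(=O)N(C)C2=O)c2ccccc21`, in this assay: 37600 nM
Compound 3, `COC(=O)[C@@H](CO)NC(=O)Cn1cc(C2=C(c3c[nH]c4ccccc34)C(=O)N(C)C2=O)c2ccccc21`, in this assay: 37900 nM

The three measured compounds share one core and differ only in the group carried on the amide-type nitrogen of the side chain. Compound 1 gives the lowest of the three numbers, but its distance to the other two is small: a 1.2-fold higher number from compound 1 to compound 2 (0.09 log units; within the scatter), and a 1.2-fold higher number from compound 1 to compound 3 (0.09 log units; within the scatter). The pair of compounds 2 and 3 is closer still, a 1.0-fold higher number from compound 2 to compound 3 (0.00 log units; within the scatter). None of these three steps reaches beyond the scatter, so the three numbers are best read as one level.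

Compound 4, `COC(=O)C[C@@H](NC(=O)Cn1cc(C2=C(c3c[nH]c4ccccc34)C(=O)N(C)C2=O)c2ccccc21)C(=O)OC`, carries the change (methoxycarbonyl in place of hydrogen on a saturated chain carbon, two bonds along the chain from an amide-type nitrogen and a carbonyl carbon). Among the measured compounds shown here, the step from compound 1 to compound 3 is the closest precedent, placing a hydroxy on the same chain carbon, and it stayed within the scatter. The longer chain of compound 2 also left the number where it was. On that basis the new methoxycarbonyl is expected to leave the value near that of compound 1, with a 1.1-fold higher number from compound 1 to compound 4 (0.03 log units; within the scatter) as the expected size of the step, in no particular direction beyond the scatter. Compound 4 is therefore estimated at 33000 nM, expected to fall between 16000 nM and 68000 nM.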

Compound 4, half-maximal inhibitory concentration: 74200 nM
Compound 4: the middle estimate sits 2.2-fold (0.35 log units) below what was measured; measured number above the stated range.
By their numbers in this assay, from the lowest: compounds 1, 2, 3 and 4 (each within the scatter of the next, the first and the last beyond it).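

Among the compounds shown here, at the saturated chain carbon two bonds along the chain from an amide-type nitrogen and a carbonyl carbon, the methoxycarbonyl group gives the first step in this assay to pass beyond the scatter, with a 2.4-fold higher number from compound 1 to compound 4 (0.39 log units; beyond the scatter) for methoxycarbonyl in place of hydrogen, whereas hydroxy on that carbon stayed within it. This separation is modest and holds only against compound 1, as the other comparisons remain within the scatter: a 2.0-fold higher number from compound 3 to compound 4 (0.29 log units; within the scatter) for methoxycarbonyl in place of hydroxy, and a 2.0-fold higher number from compound 2 to compound 4 (0.30 log units; within the scatter) for the change from the 2-(methoxycarbonyl)ethyl group to the 1,2-bis(methoxycarbonyl)ethyl group. Nothing measured here accounts for the step from compound 1 to compound 4.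

The compounds shown leave open whether a carboxylic acid in place of either methoxycarbonyl group, or an amine on the same chain carbon, would stay at the level of compound 1 or go with compound 4. They also leave open whether a longer chain between this carbon and the methoxycarbonyl group, or the opposite configuration at this carbon, would change the number in this assay at all.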